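A few compounds are considered here, and "the series" means these few. Any claim that something is new, unique, unknown or untested is made for them only; others in the source may bear on it.

Measured in an ADME assay on MT4 cells (Homo sapiens) for cytotoxicity, read by spectrophotometry, with a stated time of 5 days; on this read-out lower numbers stand for higher toxicity in this test and higher numbers for lower toxicity in this test:
- compound 1 `CONC(=S)N/N=C1\C(=O)N(CN2CCN(c3ccc(OC)cc3)CC2)c2ccc(C)cc21`: 324000 nM
- compound 2 `Cc1ccc2c(c1)/C(=N/NC(=S)NO)C(=O)N2CN1CCN(c2ccccc2)CC1`: 420000 nM
- compound 3 `CONC(=S)N/N=C1\C(=O)N(CN2CCN(c3ccccc3)CC2)c2ccc(F)cc21`: 227000 nM

Compound 3, at 227000 nM, stands within the usual scatter of both compound 1 and compound 2, so the three values do not separate in this assay.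

Compound 4 `CONC(=S)N/N=C1\C(=O)N(CN2CCN(c3ccccc3)CC2)c2ccc(C)cc21` is still unmeasured. It differs from compound 3 by methyl in place of fluoro on an aromatic carbon.

For the measured compounds named here, no two measured compounds differ in one place only, so this swap has no direct precedent here. The closest guide is compound 1, which carries a methyl on the shared core and gives 324000 nM. Compound 2 also carries that methyl and gives 420000 nM. With all three values this close, no step beyond the scatter is expected. The estimated change is a 1.3-fold higher number from compound 3 to compound 4 (0.12 log units; within the scatter), which is expected to stay within the scatter. For compound 4 the expected value is 300000 nM, with an estimated range of 170000 nM to 520000 nM.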

Compound 4, half-maximal cytotoxic concentration: 276000 nM
The estimate for compound 4 lay 1.1-fold (0.04 log units) above the measured number, and the stated range covers the measured number.
By their numbers in this assay, from the lowest: compounds 3, 4, 1 and 2 (each within the scatter of the next).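

In this assay, methyl in place of fluoro on an aromatic carbon gives a 1.2-fold higher number from compound 3 to compound 4 (0.08 log units; within the scatter), so this position of the shared core does not separate the two groups on this read-out. The two other single-place changes read the same way: methyl in place of hydrogen on an oxygen gives a 1.5-fold lower number from compound 2 to compound 4 (0.18 log units; within the scatter), and hydrogen in place of methoxy on an aromatic carbon gives a 1.2-fold lower number from compound 1 to compound 4 (0.07 log units; within the scatter), so none of the three changes moves the number beyond the scatter. No measurement at hand bears on these small steps.

Open, on these data alone, is whether a nitrile or a carboxylic acid on that aromatic carbon, or a longer chain on the oxygen, would give a step beyond the scatter. Also open, as far as these compounds go, is how an amine in place of methoxy in compound 1 would read.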